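Working notes: trimming the amide portion of compound 2

This account rests on a few compounds, and the source may have more. Where it says the series, first, only, none or still open, it means among the compounds named here.

Measured so far:
compound 1 `CCOC(=O)CN(c1nc(Cl)nc2c1ncn2C1CCCCO1)C1CC1`: 13%
compound 2 `N=C(N)NCCC[C@H](NC(=O)CN(c1nc(Cl)nc2c1ncn2C1CCCCO1)C1CC1)C(=O)OCc1ccccc1`: 61.6%

In a functional assay on the whole organism with Mus musculus as the target, with a stated time of 90 min, at a dose of 25 umol/kg by the oral route (on this read-out higher numbers stand for a stronger effect at the one dose given and lower numbers for a weaker effect), compound 2 holds the higher of the two numbers, and compound 1 sits lower by a margin beyond the usual scatter. The group that sets the two apart is the amino-acid part carried on the amide.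

The unmeasured compound 3 `O=C(CN(c1nc(Cl)nc2c1ncn2C1CCCCO1)C1CC1)NCC(=O)OCc1ccccc1` keeps the benzyl ester and the amide of compound 2 but differs from it by a hydrogen atom in place of a group of 7 heavy atoms (4 carbon, 3 nitrogen; no ring), on a saturated chain carbon bound to an amide-type nitrogen and a carbonyl carbon. Going by the values given here, no single-change step between measured compounds is available, so the size of this step rests on the two values alone. Since the group that leaves is what distinguishes compound 2 from the weaker compound 1, its loss is expected to bring the number down, most likely beyond the scatter, though not necessarily all the way to compound 1.

For compound 3 the estimate in this assay is 30%, with a range from 10% to 55%. The expected step is a number 31.6 percentage points lower from compound 2 to compound 3 (beyond the scatter).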

Compound 3, a percentage reported as activity, at one dose (the size of the read-out at that dose, not a potency): 25.9%
The estimate for compound 3 lay 4.1 percentage points above the measured number, and the stated range covers the measured number.
By their numbers in this assay, from the lowest: compound 1; then compound 3; then compound 2.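

In this assay, going by these compounds alone, a hydrogen atom in place of the group of 7 heavy atoms (4 carbon, 3 nitrogen; no ring), on a saturated chain carbon bound to an amide-type nitrogen and a carbonyl carbon, gives a number 35.7 percentage points lower from compound 2 to compound 3 (beyond the scatter) at the one dose given, the first single-change reading at this position. With the benzyl ester and the amide kept, the size of the read-out therefore depends on this group, which compound 1 and compound 2 could not show, since they differ in more than one place. Nothing at hand bears on the reason for this step.

As far as these compounds go, whether a methyl group, or a shorter chain ending in a primary amine, would keep part of the read-out at this carbon remains open. Also open, from the compounds shown here alone, is how a carboxylic acid in place of the benzyl ester would read on either side of this step.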